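Trifluoromethoxy position shift on the benzyl ether arm

The source may hold more compounds than are shown below. What is called first, only, known or untested is meant among the compounds shown, and "the series" means these compounds.

Three analogues with the same core and differing aryl groups have numbers in a functional assay on cells for inhibition of growth hormone secretagogue receptor type 1 (Homo sapiens), read by FLIPR and calcium flux; on this read-out lower numbers stand for an effect already at smaller amounts and higher numbers for an effect only at larger amounts of compound: compound 1 `CC(C)(N)C(=O)N[C@H](COCc1ccc(F)cc1F)c1nnnn1CCOC(=O)NCCCCO` gives 0.42 nM, compound 2 `CC(C)(N)C(=O)N[C@H](COCc1cc(Cl)cc(Cl)c1)c1nnnn1CCOC(=O)NCCCCO` gives 6.75 nM and compound 3 `CC(C)(N)C(=O)N[C@H](COCc1cccc(OC(F)(F)F)c1)c1nnnn1CCOC(=O)NCCCCO` gives 3.1 nM. Compound 3 thus stands second highest of the three numbers, with a 2.2-fold lower number from compound 2 to compound 3 (0.34 log units; beyond the scatter) and a 7.4-fold higher number from compound 1 to compound 3 (0.87 log units; beyond the scatter).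

Compound 4 `CC(C)(N)C(=O)N[C@H](COCc1ccc(OC(F)(F)F)cc1)c1nnnn1CCOC(=O)NCCCCO` differs from compound 3 only in 4-(trifluoromethoxy)phenyl in place of 3-(trifluoromethoxy)phenyl on a saturated chain carbon bound to an oxygen on a saturated carbon. Going by the values given here, no measured step relocates a substituent on an otherwise unchanged ring; the known steps of a 16-fold higher number from compound 1 to compound 2 (1.21 log units; beyond the scatter), a 7.4-fold higher number from compound 1 to compound 3 (0.87 log units; beyond the scatter) and a 2.2-fold lower number from compound 2 to compound 3 (0.34 log units; beyond the scatter) exchange whole aryl patterns and show the read-out responds to this part of the molecule, but they give no direction for a positional shift. A modest step at most is therefore expected in this assay for compound 4, namely a 1.3-fold higher number from compound 3 to compound 4 (0.11 log units; within the scatter), with direction uncertain.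

Compound 4 is estimated at 4 nM, range 1.5 nM to 12 nM.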

Compound 4, half-maximal effective concentration: 33.2 nM
The estimate for compound 4 lay 8.3-fold (0.92 log units) below the measured number; measured number above the stated range.
By their numbers in this assay, from the lowest: compound 1; then compound 3; then compound 2; then compound 4.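

Moving the trifluoromethoxy group on the ring, with the same atoms joined differently, is by itself a large change in this assay, with an 11-fold higher number from compound 3 to compound 4 (1.03 log units; beyond the scatter). The whole-pattern comparisons, a 4.9-fold higher number from compound 2 to compound 4 (0.69 log units; beyond the scatter) and a 79-fold higher number from compound 1 to compound 4 (1.90 log units; beyond the scatter), leave compound 4 with the highest number of the four. No measurement shown accounts for this shift.

Open, going by these compounds, is whether the same dependence on ring placement holds for a trifluoromethyl or a methoxy group in place of trifluoromethoxy.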